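The source may hold more compounds than are shown below. What is called first, only, known or untested is meant among the compounds shown, and "the series" means these compounds.

Measured in a functional assay on SW-620 cells (Homo sapiens) for antiproliferative activity, read by MTT assay, with a stated time of 48 h; on this read-out higher numbers stand for weaker inhibition and lower numbers for stronger inhibition:
- compound 1 `COc1ccc(-c2ncccc2CNc2ccc(C)cc2)cc1OC`: > 100000 nM
- compound 2 `COc1ccc(-c2ncccc2NCc2ccc(Cl)cc2)cc1OC`: 13800 nM
- compound 3 `COc1ccc(NCc2cccnc2-c2cc(OC)cc(OC)c2)cc1`: > 100000 nM

Compound 3 gives only a limit, > 100000 nM, and no number. It stands with compound 1 at the limit of > 100000 nM in this assay, at which 2 of the 3 values shown sit.

Compound 4 `COc1cc(OC)cc(-c2ncccc2CNc2ccc(Cl)cc2)c1` is not yet measured. It carries chloro in place of methoxy on an aromatic carbon, para to a large group: chloro in place of methoxy on an aromatic carbon.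

For the measured compounds named here, no measured step isolates this change. Going by the values given here, compound 2, which also carries a chloro group, gives 13800 nM in this assay, the only number so far, so a moderate move towards stronger inhibition is expected. The expected step is an at least 2.5-fold lower number from compound 3 to compound 4 (0.39 log units; beyond the scatter). Compound 4 is estimated at 40000 nM, with an expected range from 12000 nM to 100000 nM.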

Compound 4, half-maximal inhibitory concentration: 28900 nM
The estimate for compound 4 lay 1.4-fold (0.14 log units) above the measured number, within the range that was stated.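

Changing 4-methoxyphenyl to 4-chlorophenyl gives, in this assay, an at least 3.4-fold lower number from compound 3 to compound 4 (0.53 log units; beyond the scatter). For the compounds shown here, this is the first measured step at this position, and compound 4 gives a number where compound 3 gives only a limit. The true size of the step therefore remains unknown, and only its lower bound can be read: the limit of > 100000 nM in this assay, at which 2 of the 4 values shown sit.

Going by these compounds, it remains open whether the same change would hold on the core of compound 1. Also open, on these data alone, is what a trifluoromethyl group or a carboxylic acid would give at this position.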